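Lengthening the Alkyne Ether Chain on a Shared Core

The compounds below may be only part of what the source reports. "The series", "measured", "known", "first", "only" and "open" are said of these compounds alone.

Compound 1, `C#CCCCOc1ccc2cc(C(=O)O)c(=O)oc2c1`, gives in an assay on cells for inhibition of Amine oxidase [flavin-containing] A (Homo sapiens), read by Amplex Red, with stated times of 30 min and 45 min (on this read-out higher numbers stand for weaker inhibition and lower numbers for stronger inhibition), only a limit of the assay, > 10000 nM.
Compound 2, `C#CCCCOc1ccc2c(C)cc(=O)oc2c1`, gives in this assay a value of 553 nM.
Compound 3, `C#CCCCCOc1ccc2cc(NC(C)=O)c(=O)oc2c1`, gives in this assay a value of 66.8 nM.

Among the two numbers, compound 2 holds the higher one, and compound 3 sits lower; no single-change step links these two, so their values speak only for themselves. Compound 4, `C#CCCCCOc1ccc2c(C)cc(=O)oc2c1`, is not yet measured. It differs from compound 2 by propargyl in place of ethynyl on a saturated chain carbon, three bonds along the chain from an oxygen on an aromatic ring. Among the measured compounds shown here, no measured step isolates this kind of chain lengthening, so only a small change is expected, at most a modest move toward lower numbers, with the step from compound 2 to compound 4 estimated as a 1.7-fold lower number from compound 2 to compound 4 (0.24 log units; within the scatter). Compound 4 is therefore expected to give about 320 nM, with a range from 100 nM to 1200 nM.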

Compound 4, half-maximal inhibitory concentration: 59.9 nM
The estimate for compound 4 lay 5.3-fold (0.73 log units) above the measured number; the measured number lies below the stated range.
By their numbers in this assay, from the lowest: compounds 4 and 3 (each within the scatter of the next); then compound 2. At a limit, above all of these: compound 1.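

Lengthening the ether chain on the shared core from pent-4-yn-1-yl to hex-5-yn-1-yl gives, in this assay, a 9.2-fold lower number from compound 2 to compound 4 (0.97 log units; beyond the scatter). This chain position is therefore sensitive: one added carbon, with the triple bond kept at the chain end, clearly changes the read-out. Nothing measured here accounts for the size of this step.

A single step cannot show whether a longer chain, such as hept-6-yn-1-yl, would lower the number further or raise it again. On these data alone, it also remains open whether a chain ending in an amine would behave like hex-5-yn-1-yl.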